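The compounds below may be only part of what the source reports. "The series", "measured", "known", "first", "only" and "open" are said of these compounds alone.

Measured compounds:
compound 1, `CCOC(=O)/C=C/c1ccncc1-c1ccc2[nH]ccc2c1`: 100%
compound 2, `CNC(=O)/C=C/c1ccncc1-c1ccc2c(cnn2C)c1`: 98%

Two compounds have been run in an assay on a protein complex for inhibition of CDK8/Cyclin C (Homo sapiens), with a stated time of 1 h, tested at 10 uM; on this read-out higher numbers stand for more inhibition at the one concentration tested (going by the name of the read-out) and lower numbers for less inhibition. Compound 1 gives 100% in this assay. Compound 2 gives 98% in this assay, which is the smaller of the two numbers but sits within the usual scatter of the number for compound 1, so the two are not distinguishable. Both numbers are high at the concentration tested.

Compound 3, `CCOC(=O)/C=C/c1ccncc1-c1ccc2c(cnn2C)c1`, has not yet been measured in this assay. It differs from compound 2 in one place: ethoxy in place of methylamino on a carbonyl carbon. Going by the values given here, no step between measured compounds covers this change; compound 1 carries the ethoxy group, compound 2 the methylamino group, and both read near the top of the scale, but they differ at a second place as well, so that pair does not isolate the change. Since both measured numbers are near the ceiling, no step beyond the scatter is expected; the estimated step is no change at the digits printed from compound 2 to compound 3 (within the scatter), essentially flat. Compound 3 is expected to give 98%, within 90% to 100%.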

Compound 3, a percentage reported as inhibition, at one concentration (the size of the read-out at that concentration, not a potency): 100%
Beside the measured number, compound 3's estimate is 2 percentage points below it; measured number inside the range.
By their numbers in this assay, from the lowest: compounds 2, 1 and 3 (each within the scatter of the next).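

On the carbonyl carbon, ethoxy in place of methylamino now stands as a change at one place, with the rest of the structure held constant: in this assay the step is a number 2 percentage points higher from compound 2 to compound 3 (within the scatter). With the methylamino group and its hydrogen-bond donor gone, the read-out at this single concentration does not separate the two groups on this core, although both compounds sit near the top of the scale, so this says nothing about a gap in potency. No supporting data bear on why the two groups read alike.

Open, going by these compounds, is how a carboxylic acid or a longer alkoxy chain on this carbonyl carbon would read. Also open, on these data alone, is whether ethoxy and methylamino would separate at lower concentrations, where the read-out is clear of the top of its scale.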